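This account rests on a few compounds, and the source may have more. Where it says the series, first, only, none or still open, it means among the compounds named here.

Compound 1 `CCCC[C@H](NC(=O)[C@H](CCCCN)NC(=O)[C@H](CCCNC(=N)N)NC(=O)c1ccccc1)C(N)=O` and compound 2 `CCCC[C@H](NC(=O)[C@H](CCCCN)NC(=O)[C@H](CCCNC(=N)N)NC(=O)c1ccc(/C=C2\SC(=S)N(C3CCCC3)C2=O)cc1)C(N)=O` share the same core and were both examined in an ADME assay for permeability, using PAMPA; on this read-out higher numbers stand for higher permeability and lower numbers for lower permeability. Within the data shown here, compound 1 is reported as "impermeable" (no number reported), while compound 2 gives 2.31 10^-6 cm/s, the only value in this set that comes with a number. Compound 3 `C=CCN1C(=O)/C(=C/c2ccc(C(=O)N[C@@H](CCCNC(=N)N)C(=O)N[C@@H](CCCCN)C(=O)N[C@@H](CCCC)C(N)=O)cc2)SC1=S` differs from compound 2 in one place: allyl in place of cyclopentyl on an amide-type nitrogen in a ring. Among the measured compounds shown here, no measured pair shows a change of this kind, so its effect cannot be read from the data. The step of a 1.5-fold lower number from compound 2 to compound 3 (0.19 log units; within the scatter) is expected to be small, likely within the scatter, perhaps slightly downward. Compound 3 is expected to reach 1.5 10^-6 cm/s, within 0.5 10^-6 cm/s to 4 10^-6 cm/s.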

Compound 3, apparent permeability: 0.42 10^-6 cm/s
Compound 3: middle estimate off by 3.6-fold (0.55 log units), on the high side; the measured number lies below the stated range.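

Placing allyl instead of cyclopentyl on the amide-type nitrogen in the ring gives a 5.5-fold lower number from compound 2 to compound 3 (0.74 log units; beyond the scatter) in this assay, so the number at this position depends on the group it carries. The change removes a ring and adds a double bond outside aromatic rings, and this single pair cannot separate those two features. Nothing measured here explains the step.

Still open, as far as these compounds go, is whether a propyl chain, which has no double bond, would read closer to compound 2 or compound 3. A cyclohexyl ring on this nitrogen leaves the same question open.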